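A Benzylamine in Place of a Thioether on a Fused Core

This account rests on a few compounds, and the source may have more. Where it says the series, first, only, none or still open, it means among the compounds named here.

Compounds measured so far:
- compound 1, `CCOC(=O)[C@H](CCC(=O)O)NC(=O)c1ccc(Sc2nc3cc(N)cc(N)c3nc2-c2ccccc2)cc1`: in a functional assay on OVCAR-5 cells (Homo sapiens) for inhibition, read by sulforhodamine B assay, with a stated time of 48 h (a higher number here means that more compound is tolerated, a lower number that less compound is tolerated), compound 1 gives < 100000 nM, which is a limit of the assay and not a number.
- compound 2, `Nc1cc(N)c2nc(-c3ccccc3)c(Sc3ccc(F)cc3)nc2c1`: in this assay compound 2 gives < 100000 nM, again a limit rather than a number.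
- compound 3, `COc1cc(CNc2nc3cc(N)cc(N)c3nc2-c2ccccc2)cc(OC)c1OC`: in this assay compound 3 gives < 50200 nM, also a limit.

Compound 2 therefore stands nowhere definite on the numbers shown: its value is only a limit, and the two other values are limits as well. Two of the three sit at the limit of < 100000 nM in this assay, at which 2 of the 3 values shown sit, and one at the limit of < 50200 nM in this assay, at which 1 of the 3 values shown sits, so no ordering among the three compounds can be read from these data.

Compound 4, `Nc1cc(N)c2nc(-c3ccccc3)c(NCc3ccc(F)cc3)nc2c1`, has not yet been measured in this assay. It differs from compound 2 in one place: (4-fluorobenzyl)amino in place of (4-fluorophenyl)sulfanyl on an aromatic carbon. Within the data shown here, no step between measured compounds is available to show what such a change does. With every value a limit, the expected step from compound 2 is a step that the limit leaves unreadable from compound 2 to compound 4, that is, none that can be told beyond the scatter, and the result may well again be a limit. Compound 4 is estimated at 50000 nM, with a range from 5000 nM to 100000 nM.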

Compound 4, concentration lethal to 50% of the cells: < 100000 nM
Compound 4: only a limit was reported; the forecaster's own chance of this, stated with the estimate: 60%; the middle value lies beyond the limit too.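

In this assay compound 2 gives < 100000 nM, which is a limit and not a number. Among these compounds, compound 4 gives < 100000 nM, again a limit, so no step between these two compounds can be read. The compounds shown leave open whether (4-fluorobenzyl)amino in place of (4-fluorophenyl)sulfanyl changes the lethal concentration at all.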